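Compound 3: dimethylamino in place of 3-chlorophenyl

A few compounds are considered here, and "the series" means these few. Any claim that something is new, unique, unknown or untested is made for them only; others in the source may bear on it.

Compound 1 `CC(=O)n1nc(NC(=O)c2ccccc2)c2c1CN(C(=O)c1cccc(F)c1)C2`: 21900 nM
Compound 2 `CC(=O)n1nc(NC(=O)c2ccccc2)c2c1CN(C(=O)c1cccc(Cl)c1)C2`: 17400 nM
Compound 3 `CC(=O)n1nc(NC(=O)c2ccccc2)c2c1CN(C(=O)N(C)C)C2`: not yet measured

All values come from a functional assay on HCT-116 cells (Homo sapiens) for cytotoxicity, read by sulforhodamine B assay, with a stated time of 48 h; on this read-out higher numbers stand for weaker inhibition and lower numbers for stronger inhibition. Among the compounds with values here, the only measured step is a 1.3-fold lower number from compound 1 to compound 2 (0.10 log units; within the scatter), which lies within the scatter. Compound 2 therefore stands level with compound 1, and no order can be drawn between them.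

Compound 3 carries dimethylamino in place of 3-chlorophenyl on a carbonyl carbon. Within the data shown here, the measured step only exchanged chloro for fluoro on an aromatic carbon, so it bears on this change only loosely, and the data hold no step that removes the aromatic ring. Starting from compound 2 at 17400 nM, a small move toward a higher number is expected. The estimated step is a 1.7-fold higher number from compound 2 to compound 3 (0.24 log units; within the scatter). Compound 3 is expected at 30000 nM, with an estimated range of 12000 nM to 80000 nM.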

Compound 3, half-maximal inhibitory concentration: 70300 nM
Estimate against measurement, compound 3: 2.3-fold (0.37 log units) below, within the range that was stated.
By their numbers in this assay, from the lowest: compounds 2 and 1 (each within the scatter of the next); then compound 3.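

In this assay, dimethylamino in place of 3-chlorophenyl on the carbonyl carbon gives a clear change (a 4.0-fold higher number from compound 2 to compound 3 (0.61 log units; beyond the scatter)), and dimethylamino in place of 3-fluorophenyl gives a similar one (a 3.2-fold higher number from compound 1 to compound 3 (0.51 log units; beyond the scatter)). Unlike the exchange of chloro for fluoro, this change at the position moves the number beyond the scatter, and both steps run toward weaker inhibition, although they are modest. The evidence available offers no explanation for this shift.

As far as these compounds go, it remains open whether the higher number follows from the loss of the aromatic ring or from the dimethylamino group itself. From the compounds shown here alone, how an unsubstituted phenyl, a morpholine or a simple methyl on this carbonyl carbon would read also remains unknown.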